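Swapping the aryl group on the hydrazone carbon

The source may hold more compounds than are shown below. What is called first, only, known or untested is meant among the compounds shown, and "the series" means these compounds.

Compounds measured so far in an assay on isolated protein for inhibition of Maltase-glucoamylase (Homo sapiens), with a stated time of 15 min; a higher number here means a weaker inhibitor, a lower number a stronger inhibitor:
Compound 1, `O=C(N/N=C/c1cccs1)c1ccc(-c2nc3ccccc3s2)cc1`, gives 8480 nM.
Compound 2, `COc1ccc(/C=N/NC(=O)c2ccc(-c3nc4ccccc4s3)cc2)c(O)c1`, gives 6970 nM.
Compound 3, `COc1cc(/C=N/NC(=O)c2ccc(-c3nc4ccccc4s3)cc2)cc(OC)c1`, gives 16200 nM.

Compound 3 carries the highest number of the three. One step, a 1.9-fold higher number from compound 1 to compound 3 (0.28 log units; within the scatter), stays within the scatter, while the other, a 2.3-fold higher number from compound 2 to compound 3 (0.37 log units; beyond the scatter), is a modest but real difference. The unmeasured compound 4, `O=C(N/N=C/c1cccc(O)c1)c1ccc(-c2nc3ccccc3s2)cc1`, differs from compound 3 in one place: 3-hydroxyphenyl in place of 3,5-dimethoxyphenyl on a carbon with a double bond to nitrogen. For the measured compounds named here, the steps that bear on this change are those at the same position: a 1.2-fold lower number from compound 1 to compound 2 (0.09 log units; within the scatter) and a 2.3-fold higher number from compound 2 to compound 3 (0.37 log units; beyond the scatter). The 2-hydroxy-4-methoxyphenyl of compound 2 gave the lowest number seen, and compound 4 likewise brings a hydroxy-bearing phenyl. Compound 4 is therefore expected to give a step of a 1.8-fold lower number from compound 3 to compound 4 (0.26 log units; within the scatter) in this assay, towards a lower number, of roughly the size seen before. The estimate for compound 4 is 9000 nM, with a range from 4000 nM to 20000 nM.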

Compound 4, half-maximal inhibitory concentration: 9210 nM
Compound 4: middle estimate off by 1.0-fold (0.01 log units), on the low side; measured number inside the range.
By their numbers in this assay, from the lowest: compounds 2, 1, 4 and 3 (each within the scatter of the next, the first and the last beyond it).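

In this assay, the 3-hydroxyphenyl of compound 4 cannot be told apart from the two groups at the low end of the series, with a 1.3-fold higher number from compound 2 to compound 4 (0.12 log units; within the scatter) and a 1.1-fold higher number from compound 1 to compound 4 (0.04 log units; within the scatter). Replacing the 3,5-dimethoxyphenyl also gives only a 1.8-fold lower number from compound 3 to compound 4 (0.25 log units; within the scatter), so compound 4 lies within the scatter of every other compound, and the gap between compound 2 and compound 3 remains the only one beyond it. A hydroxy-bearing phenyl therefore does not set a compound apart here, since compound 1, with thiophen-2-yl and no hydroxy group, lies within the scatter of both hydroxy-bearing compounds.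

No measurement shown accounts for these small differences. Going by these compounds, it remains open whether an amine or a carboxylic acid on the phenyl ring, or a longer chain in place of the ring, would move the number beyond this narrow band.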